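Trimethoxyphenyl pyrazoline series: one methoxy removed

The source may report more compounds than this note shows. Statements on the series, on what has been measured and on what is new or still open speak of the compounds shown alone.

Measured compounds and values in a functional assay on IMR-32 cells (Homo sapiens) for cytotoxicity, read by sulforhodamine B assay, with a stated time of 48 h; on this read-out lower numbers stand for stronger inhibition and higher numbers for weaker inhibition:
compound 1, `CC(=O)N1N=C(c2cccc([N+](=O)[O-])c2)CC1c1ccccc1`, 7890 nM
compound 2, `COc1ccc(C2CC(c3cccc([N+](=O)[O-])c3)=NN2C(C)=O)cc1`, 6650 nM
compound 3, `COc1ccc(C2CC(c3cccc4ccccc34)=NN2C(C)=O)c(OC)c1OC`, 1790 nM

Compound 1 and compound 2 share a core and differ in one place: hydrogen in place of methoxy on an aromatic carbon. The step is a 1.2-fold higher number from compound 2 to compound 1 (0.07 log units; within the scatter), so the two values do not separate. Compound 3 carries a different core; how it differs from compound 2 is not broken down here. In this assay compound 3 gives the lowest of the three numbers, and its gap to compound 2 as well as to compound 1 is beyond the scatter.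

Compound 4, `COc1ccc(C2CC(c3cccc4ccccc34)=NN2C(C)=O)cc1OC`, is not yet measured. It differs from compound 3 by hydrogen in place of methoxy on an aromatic carbon. This is the same kind of change as from compound 2 to compound 1, but the surroundings of the place are not the same: in compound 2 the leaving methoxy sits para to a large group, whereas in compound 3 it sits ortho to a large group, ortho to a methoxy group and meta to a methoxy group. Among the measured compounds shown here, the only measured precedent for this kind of change is a 1.2-fold higher number from compound 2 to compound 1 (0.07 log units; within the scatter), which is within the scatter, so a small step is expected from compound 3 to compound 4, estimated as a 1.4-fold higher number from compound 3 to compound 4 (0.15 log units; within the scatter). The wider range allows for the differing surroundings of the place. The value expected for compound 4 in this assay is therefore 2500 nM, between 1000 nM and 6500 nM.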

Compound 4, half-maximal inhibitory concentration: 1680 nM
For compound 4 the middle estimate is 1.5-fold (0.17 log units) above the measured one; the measured number falls inside the stated range.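

In this assay, the new step is a 1.1-fold lower number from compound 3 to compound 4 (0.03 log units; within the scatter), so hydrogen in place of methoxy on an aromatic carbon does not separate the values of this pair. Set beside the earlier step, the two cores give no different reading of this change: the same change on two cores in this assay, a 1.2-fold higher number (0.07 log units; within the scatter) from compound 2 to compound 1 and a 1.1-fold lower number (0.03 log units; within the scatter) from compound 3 to compound 4, 1.3-fold (0.10 log units) apart, within the scatter of two such steps

Among the compounds shown here, this supports carrying the change between these two cores with little expected movement in this read-out, but it rests on only two steps, each taken at one place in its own surroundings, and it does not show that any methoxy group on either core can be replaced without consequence, nor does a step within the scatter give any reason for the lack of movement.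

Still open, on these data alone, is whether the other two methoxy groups of compound 3 can be lost in the same way, alone or together, and whether a hydroxy group, a fluorine atom, an amine or a longer chain such as ethoxy at the same place would stay as close to the value of compound 3 as hydrogen does. Also open, as far as these compounds go, is whether a group other than the acetyl carried by all four compounds would leave this picture intact.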